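This account rests on a few compounds, and the source may have more. Where it says the series, first, only, none or still open, it means among the compounds named here.

Measured so far, in an in vivo ADME assay on the whole organism (strain Sprague-Dawley) for metabolic stability, with Rattus norvegicus as the target, at a dose of 2 mg/kg by the intravenous route; on this read-out lower numbers stand for a shorter-lived compound and higher numbers for a longer-lived compound:
- compound 1, `Cc1nc(-c2c(F)cccc2-c2ccc([C@@H](C)Nc3nccc(Cl)c3NC(=O)CC#N)cc2)no1`: compound 1 gives 12.9 h
- compound 2, `COC(=O)c1ccc(Cl)cc1-c1ccc([C@@H](C)Nc2nccc(Cl)c2NC(=O)CC#N)cc1`: compound 2 gives 0.5 h

Compound 2 stands lowest of the two numbers; its nearest neighbour, compound 1, gives the higher number, and that gap lies beyond the scatter. Compound 3, `COC(=O)c1c(Cl)cccc1-c1ccc([C@@H](C)Nc2nccc(Cl)c2NC(=O)CC#N)cc1`, is not yet measured. It differs from compound 2 in one place: 3-chloro-2-(methoxycarbonyl)phenyl in place of 5-chloro-2-(methoxycarbonyl)phenyl on an aromatic carbon. For the measured compounds named here, no measured pair shows a step of this kind, so direction is unknown; the expected step is a 1.6-fold higher number from compound 2 to compound 3 (0.20 log units; within the scatter), none beyond the scatter. Compound 3 is thus estimated at 0.8 h, with a range from 0.3 h to 2.5 h.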

Compound 3, half-life: 1.3 h
Estimate against measurement, compound 3: 1.6-fold (0.21 log units) below; low and high end bracket the measured number.
By their numbers in this assay, from the lowest: compound 2; then compound 3; then compound 1.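

In this assay, 3-chloro-2-(methoxycarbonyl)phenyl in place of 5-chloro-2-(methoxycarbonyl)phenyl gives a 2.6-fold higher number from compound 2 to compound 3 (0.41 log units; beyond the scatter). The two groups have the same atoms and counts, so at this position the placement of the chlorine alone is enough to shift the half-life. Nothing available explains this step.

From the compounds shown here alone, whether the 3-chloro group gives the same step with a carboxylic acid or a primary amide in place of the methoxycarbonyl remains open. Fluorine or methyl in place of the chlorine is equally open.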